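Fluoro for chloro on a weak growth inhibitor

The source may report more compounds than this note shows. Statements on the series, on what has been measured and on what is new or still open speak of the compounds shown alone.

In a functional assay on DU-145 cells (Homo sapiens) for inhibition, read by trypan blue exclusion, with a stated time of 96 h (a higher number here means a weaker inhibitor of growth, a lower number a stronger inhibitor of growth), compound 1 (`O=C(/C(=C\c1c[nH]c2ccc(Cl)cc12)SCc1ccc(F)cc1)c1ccc(Br)cc1`) gives 1000 nM while compound 2 (`COc1ccc(/C=C(/SCc2ccc(Cl)cc2)C(=O)c2ccc(Br)cc2)cc1`) gives 10000 nM as the higher of the two numbers. That gap lies beyond the usual scatter and places compound 2 as the weaker inhibitor of growth. The two compounds differ in more than one place, so the gap cannot be tied to any single group. Compound 3 (`COc1ccc(/C=C(/SCc2ccc(F)cc2)C(=O)c2ccc(Br)cc2)cc1`) departs from compound 2 by one exchange (fluoro in place of chloro on an aromatic carbon) with fluoro in place of chloro on an aromatic carbon, para to a large group. Going by the values given here, no measured pair shows this exchange, so the expectation rests on the exchange alone. In this assay the estimate is a 1.3-fold lower number from compound 2 to compound 3 (0.10 log units; within the scatter) and this expected step stays within the scatter. For compound 3 the estimated value is 8000 nM within an expected range of 3000 nM to 20000 nM on this read-out.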

Compound 3, concentration for 50% growth inhibition: 50000 nM
Beside the measured number, compound 3's estimate is 6.3-fold (0.80 log units) below it; the measured number lies above the stated range.
By their numbers in this assay, from the lowest: compound 1; then compound 2; then compound 3.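

In this assay, the change from (4-chlorobenzyl)sulfanyl to (4-fluorobenzyl)sulfanyl gives a 5.0-fold higher number from compound 2 to compound 3 (0.70 log units; beyond the scatter), so this one halogen exchange, para to a large group, measurably weakens growth inhibition in this pair. With fluoro held constant, 4-methoxyphenyl in place of 5-chloro-1H-indol-3-yl gives a 50-fold higher number from compound 1 to compound 3 (1.70 log units; beyond the scatter), a larger step that shows the second place also matters on this core. Nothing available explains either step.

On these data alone, it remains open how a hydrogen, a methyl or a trifluoromethyl at the same aromatic carbon would compare with chloro and fluoro. As far as these compounds go, it is also open whether the exchange of chloro for fluoro would carry the same step with 5-chloro-1H-indol-3-yl in place of 4-methoxyphenyl.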